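The compounds below may be only part of what the source reports. "The series", "measured", "known", "first", "only" and "open" are said of these compounds alone.

Compound 2 `c1ccc(-c2ccsc2)c(OCC2=NCCN2)c1` was tested in a functional assay for activation of Alpha-1D adrenergic receptor (Homo sapiens), read by calcium flux (on this read-out higher numbers stand for an effect only at larger amounts of compound and lower numbers for an effect already at smaller amounts), where compound 2 gives 12.6 nM. Among the compounds with values here, its only measured neighbour is compound 1 `c1csc(-c2ccccc2OCC2=NCCN2)c1`, which in this assay gives 15.9 nM. The step of a 1.3-fold lower number from compound 1 to compound 2 (0.10 log units; within the scatter) is within the scatter, so the two numbers sit together and neither stands apart from the other. Compound 3 `Cc1ccc(-c2ccccc2OCC2=NCCN2)s1` has not been measured. It differs from compound 2 in one place: 5-methylthiophen-2-yl in place of thiophen-3-yl on an aromatic carbon. Part of this change, the swap between thiophen-2-yl and thiophen-3-yl, is the kind of change seen in a 1.3-fold lower number from compound 1 to compound 2 (0.10 log units; within the scatter), which did not move the number beyond the scatter. The methyl that 5-methylthiophen-2-yl carries has no measured counterpart among these compounds. The expectation for compound 3 is therefore a step of about a 1.2-fold higher number from compound 2 to compound 3 (0.08 log units; within the scatter), not beyond the scatter. Compound 3 is thus estimated at 15 nM, with a range from 5 nM to 50 nM.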

Compound 3, half-maximal effective concentration: < 100000 nM
Compound 3 was reported as a limit (the forecaster's own chance of this, stated with the estimate: 3%); the middle value does not contradict the limit.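

In this assay compound 3 gives < 100000 nM, which is a limit and not a number. The steps to compound 3 from compound 1 and compound 2 therefore cannot be read. The compounds shown leave open whether the methyl of 5-methylthiophen-2-yl changes the number at all.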